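This account rests on a few compounds, and the source may have more. Where it says the series, first, only, none or still open, it means among the compounds named here.

The measured compounds are compound 1 `CC1=CC[C@H](C(C)(C)NC(=S)N/N=C/c2ccc(O)cc2)CC1` and compound 2 `CC1=CC[C@H](C(C)(C)NC(=S)N/N=C/c2cccc(Cl)c2)CC1`. In a functional assay on UACC-62 cells (Homo sapiens) for inhibition, read by sulforhodamine B assay, with a stated time of 48 h (on this read-out higher numbers stand for weaker inhibition of growth and lower numbers for stronger inhibition of growth), compound 1 gives only a limit, > 100000 nM. In this assay compound 2 gives 9000 nM. Compound 2 therefore holds the only number shown in this assay; the other value is a limit, so compound 2 is the single measured point from which any expectation must start. Among the measured compounds shown here, the one measured step, an at least 11-fold lower number from compound 1 to compound 2 (1.04 log units; beyond the scatter), is large, and with the limit of > 100000 nM in this assay, at which 1 of the 2 values shown sits, its true size is not known.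

Compound 3 `CC1=CC[C@H](C(C)(C)NC(=S)N/N=C/c2ccco2)CC1` differs from compound 2 by furan-2-yl in place of 3-chlorophenyl on a carbon with a double bond to nitrogen. The measured step bears on this change only in that it also exchanges the group on the carbon with a double bond to nitrogen; it was large, so the group at that place matters, but it gives no direct guide for a furan-2-yl. A moderate step toward a higher number is expected, a 2.8-fold higher number from compound 2 to compound 3 (0.44 log units; beyond the scatter), with a real chance that only a limit is reported. Compound 3 is estimated at 25000 nM, in the range 8000 nM to 100000 nM.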

Compound 3, concentration for 50% growth inhibition: 10700 nM
Compound 3: the middle estimate sits 2.3-fold (0.37 log units) above what was measured, and the stated range covers the measured number.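

At the carbon with a double bond to nitrogen, this assay now shows that 3-chlorophenyl can give way to furan-2-yl, a five-membered aromatic ring with a hetero atom and no chlorine, with no change beyond the scatter: a 1.2-fold higher number from compound 2 to compound 3 (0.08 log units; within the scatter). The large difference from the 4-hydroxyphenyl of compound 1 is therefore not tied to 3-chlorophenyl alone, as a second, quite different ring also stands apart from it, with an at least 9.3-fold lower number from compound 1 to compound 3 (0.97 log units; beyond the scatter). Compound 1 is known only through a limit, so the true size of both differences from it remains unknown: the limit of > 100000 nM in this assay, at which 1 of the 3 values shown sits.

The compounds shown leave open whether the hydroxyl on the phenyl ring of compound 1 is what separates it from the other two, a question that an unsubstituted phenyl, a methoxy group or a hydroxyl at another ring position would bear on. They also leave open how a pyridine ring, a thiophene ring, an amine or a carboxylic acid at this place would read, and whether any change to the shared core would move the number.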